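The source may report more compounds than this note shows. Statements on the series, on what has been measured and on what is new or still open speak of the compounds shown alone.

Measured so far:
- compound 1 `CN(Cc1ccc(-c2ccccc2)cc1)Cc1cn(C)c2ccc(CNc3ccc(F)cc3)cc12`, 34400 nM
- compound 2 `CN(Cc1cccc2ccccc12)Cc1cn(C)c2ccc(CNc3ccc(F)cc3)cc12`, 3680 nM
- compound 3 `CN(Cc1ccc(-c2ccccc2)cc1)Cc1cn(C)c2ccc(C(=O)Nc3ccc(F)cc3)cc12`, > 100000 nM

Compound 3 stands at the weak end of what has been seen. In a functional assay on Jurkat cells (Homo sapiens) for antiproliferative activity, read by MTT assay, with a stated time of 72 h (a lower number here means a stronger inhibitor, a higher number a weaker inhibitor), compound 3 gives > 100000 nM, and this is a limit of the assay, not a number. Going by the values given here, the step of an at least 2.9-fold higher number from compound 1 to compound 3 (0.46 log units; beyond the scatter) is the only measured step, and it rests on (the limit of > 100000 nM in this assay, at which 1 of the 3 values shown sits). Within the pair that shares the aminomethyl linker, compound 1 shows 34400 nM in this assay, and compound 2 shows 3680 nM in this assay.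

Compound 4 `COc1cc(CN(C)Cc2cn(C)c3ccc(C(=O)Nc4ccc(F)cc4)cc23)cc(OC)c1OC` differs from compound 3 by a single change: 3,4,5-trimethoxyphenyl in place of 4-phenylphenyl on a saturated chain carbon bound to an amine nitrogen. No measured step touches this part of the molecule while the carbamoyl linker is kept, so nothing shown bears on the change directly. Among the compounds with values here, the values of compound 1 and compound 2 show that the aryl group on that chain carbon can move the number within the aminomethyl series, but no comparable pair exists in the carbamoyl series. With compound 3 sitting at a limit, the step of an at least 1.4-fold lower number from compound 3 to compound 4 (0.15 log units; that floor lies within the scatter) is expected to be small or of unknown size, and compound 4 is estimated to remain a weak inhibitor in this assay, at 70000 nM with a range from 15000 nM to 300000 nM.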

Compound 4, half-maximal inhibitory concentration: 42100 nM
Estimate against measurement, compound 4: 1.7-fold (0.22 log units) above, within the range that was stated.
By their numbers in this assay, from the lowest: compound 2; then compounds 1 and 4 (each within the scatter of the next). At a limit, above all of these: compound 3.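

Going by these compounds alone, with the carbamoyl linker kept, this assay now shows an at least 2.3-fold lower number from compound 3 to compound 4 (0.37 log units; beyond the scatter), the first measured change on a saturated chain carbon bound to an amine nitrogen. Until now, only compound 1 and compound 2 had shown that the aryl group at this place can move the number, and both carry the aminomethyl linker; the new step shows that it also matters with the carbamoyl linker, where 3,4,5-trimethoxyphenyl, with one aromatic ring and hydrogen-bond acceptors, replaces 4-phenylphenyl, with two aromatic rings and none, at an equal heavy-atom count. The value of compound 3, > 100000 nM, is a limit of the assay and not a number, so the step gives only a floor, and its true size stays unknown: the limit of > 100000 nM in this assay, at which 1 of the 4 values shown sits.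

The compounds shown leave open whether the loss of the second aromatic ring or the arrival of the methoxy groups drives the step, which a plain phenyl or a 4-methoxyphenyl group at this place could help to separate. Also open, as far as these compounds go, is how 3,4,5-trimethoxyphenyl behaves with the ((4-fluorophenyl)amino)methyl linker.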